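The source may report more compounds than this note shows. Statements on the series, on what has been measured and on what is new or still open speak of the compounds shown alone.

Measured so far in an assay on Cerebral cortex for binding affinity to adenosine receptor A1 (Cavia porcellus), read by radioligand binding; a lower number here means a stronger inhibitor, a higher number a weaker inhibitor:
compound 1 `CCCn1c(=O)n(CC(=O)O)c(=O)c2[nH]cnc21` gives > 200000 nM;
compound 2 `CCCn1c(=O)n(CCO)c(=O)c2[nH]cnc21` gives 50000 nM.

The figure for compound 1 is a limit of this assay rather than a number. Compound 2 therefore holds the only number shown, and the step of an at least 4.0-fold lower number from compound 1 to compound 2 (0.60 log units; beyond the scatter) is the sole measured step. Compound 3 `CCCn1c(=O)n(CCOCC)c(=O)c2[nH]cnc21` differs from compound 2 by ethyl in place of hydrogen on an oxygen on a saturated carbon. The measured step touches the same chain, yet it swapped carboxy for hydroxymethyl, which does not tell how capping the hydroxy with ethyl will read. An expected step of no change at the digits printed from compound 2 to compound 3 (within the scatter) is taken to stay within the scatter. Compound 3 is estimated at 50000 nM, between 15000 nM and 170000 nM.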

Compound 3, inhibition constant: 1900 nM
Estimate against measurement, compound 3: 26-fold (1.42 log units) above; measured number below the stated range.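

In this assay, capping the hydroxy of the 2-hydroxyethyl chain with ethyl gives a 26-fold lower number from compound 2 to compound 3 (1.42 log units; beyond the scatter), so this chain responds strongly to what sits on its oxygen, which the change from carboxy to hydroxymethyl alone had not shown. Putting ethoxymethyl in place of carboxy gives an at least 100-fold lower number from compound 1 to compound 3 (2.02 log units; beyond the scatter). The figure for compound 1 is a limit, not a number: the limit of > 200000 nM in this assay, at which 1 of the 3 values shown sits.

What the compounds shown leave open is whether a methyl or a propyl on that oxygen would read the same, and whether an amine in place of the ethoxy would keep the lower number.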